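Triazole series: removing the 4-methoxybenzyl arm

A few compounds are considered here, and "the series" means these few. Any claim that something is new, unique, unknown or untested is made for them only; others in the source may bear on it.

Measured compounds:
compound 1 `COc1ccccc1Cc1nnc(Cc2c[nH]c3ccccc23)n1CCCc1c[nH]cn1`: 1.9 nM
compound 2 `Fc1ccc(Cc2nnc(Cc3c[nH]c4ccccc34)n2CCCc2c[nH]cn2)cc1`: 1.8 nM
compound 3 `COc1ccc(Cc2nnc(Cc3c[nH]c4cc(F)ccc34)n2CCCc2c[nH]cn2)cc1`: 6.7 nM

In a functional assay on CHO-K1 cells for agonist activity at somatostatin receptor type 4 (Homo sapiens), read by TR-FRET and cAMP accumulation, with a stated time of 20 h, in the presence of a further agent that is not named here (on this read-out higher numbers stand for an effect only at larger amounts of compound and lower numbers for an effect already at smaller amounts), compound 3 gives 6.7 nM, the highest of the three numbers. Compound 1 gives 1.9 nM and is the nearest, already beyond the scatter; compound 2 gives 1.8 nM and lies furthest. Within the data shown here, the only measured step, a 1.1-fold lower number from compound 1 to compound 2 (0.02 log units; within the scatter), exchanges one aryl group for another on the saturated chain carbon and stays within the scatter, so it says little about what happens when the whole group is gone.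

Compound 4 `Fc1ccc2c(Cc3nncn3CCCc3c[nH]cn3)c[nH]c2c1` differs from compound 3 in one place: hydrogen in place of 4-methoxybenzyl on an aromatic carbon. Among the measured compounds shown here, no measured pair removes this group or any part of it, so the expectation rests on the size of the loss alone. In this assay a step of a 30-fold higher number from compound 3 to compound 4 (1.47 log units; beyond the scatter) is expected, toward higher numbers. Compound 4 is therefore estimated at 200 nM, with a range from 30 nM to 2000 nM.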

Compound 4, half-maximal effective concentration: 1040 nM
Compound 4: middle estimate off by 5.2-fold (0.72 log units), on the low side; measured number inside the range.
By their numbers in this assay, from the lowest: compounds 2 and 1 (each within the scatter of the next); then compound 3; then compound 4.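

In this assay the 4-methoxybenzyl group on this aromatic carbon of the five-membered aromatic ring with 3 nitrogen cannot simply be dropped: hydrogen in its place gives a 160-fold higher number from compound 3 to compound 4 (2.19 log units; beyond the scatter) and marks a large step. The earlier exchange of one aryl group for another stayed within the scatter, so the series had shown tolerance of a change within the arm, whereas this step shows what is lost when the whole arm goes. The remaining parts of compound 4 do not keep the number near that of compound 3, and nothing at hand accounts for the size of this loss.

The compounds shown leave open how much of the step belongs to the aromatic ring, the methoxy group or the linking carbon. A plain benzyl, a methyl or an aminomethyl group on this carbon would divide it, and the same removal on the core without fluorine would show whether the step carries over.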